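This account rests on a few compounds, and the source may have more. Where it says the series, first, only, none or still open, it means among the compounds named here.

In a functional assay on MCF7 cells (Homo sapiens) for cytotoxicity, read by sulforhodamine B assay (on this read-out lower numbers stand for stronger inhibition and higher numbers for weaker inhibition), compound 3, with the structure `C=C1[C@@H](OC(C)=O)C[C@@H]2[C@](C)(CO[Si](C)(C)C(C)(C)C)[C@H](OC(C)=O)CC[C@@]2(C)[C@@H]1C[C@@H](Nc1cccc(OC)c1)C1=CCOC1=O`, gives 28100 nM, the highest of the three numbers in hand. Compound 2, `C=C1[C@@H](OC(C)=O)C[C@@H]2[C@](C)(CO[Si](C)(C)C(C)(C)C)[C@H](OC(C)=O)CC[C@@]2(C)[C@@H]1C[C@@H](Nc1ccc(Br)cc1)C1=CCOC1=O`, shares the same core but carries a 4-bromophenyl on the amine nitrogen, and in this assay compound 2 gives 3920 nM. Among the measured compounds shown here, the only single-change step among the measured compounds is a 7.2-fold higher number from compound 2 to compound 3 (0.86 log units; beyond the scatter). Compound 1, `C=C1[C@@H](OC(C)=O)C[C@@H]2[C@](C)(COC=O)[C@H](OC(C)=O)CC[C@@]2(C)[C@@H]1C[C@@H](Nc1ccc(O)cc1)C1=CCOC1=O`, has a different group on the core and a 4-hydroxyphenyl on the amine nitrogen; in this assay compound 1 gives 18100 nM, which sits within the scatter of compound 3.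

Compound 4, `C=C1[C@@H](OC(C)=O)C[C@@H]2[C@](C)(CO[Si](C)(C)C(C)(C)C)[C@H](OC(C)=O)CC[C@@]2(C)[C@@H]1C[C@@H](Nc1ccc(O)cc1)C1=CCOC1=O`, differs from compound 3 in one place: 4-hydroxyphenyl in place of 3-methoxyphenyl on an amine nitrogen. For the measured compounds named here, no measured step follows exactly this change on this core. The nearest guide is compound 1, whose 4-hydroxyphenyl and 18100 nM sit close to compound 3, so a small step, if any, seems likely, with the bromophenyl step from compound 2 to compound 3 offering no direct read. Compound 4 is therefore expected to give about 18000 nM in this assay, within a range of 6000 nM to 55000 nM. That estimate means a step of a 1.6-fold lower number from compound 3 to compound 4 (0.19 log units; within the scatter), which is expected to stay within the scatter.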

Compound 4, half-maximal inhibitory concentration: 5220 nM
The estimate for compound 4 lay 3.4-fold (0.54 log units) above the measured number; measured number outside the range, below it.
By their numbers in this assay, from the lowest: compounds 2 and 4 (each within the scatter of the next); then compounds 1 and 3 (each within the scatter of the next).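

In this assay, putting 4-hydroxyphenyl in place of 3-methoxyphenyl on the amine nitrogen gives a 5.4-fold lower number from compound 3 to compound 4 (0.73 log units; beyond the scatter) and so shows that the group at this position can shift the number on this core. Hydroxy in place of bromo on the aromatic carbon gives a 1.3-fold higher number from compound 2 to compound 4 (0.12 log units; within the scatter) and stays within the scatter, so 4-hydroxyphenyl and 4-bromophenyl cannot be told apart here, while 3-methoxyphenyl stands apart from both. With 4-hydroxyphenyl held constant, the group of 7 heavy atoms (6 carbon, 1 silicon) on the oxygen in place of the group of 2 heavy atoms (1 carbon, 1 oxygen) gives a 3.5-fold lower number from compound 1 to compound 4 (0.54 log units; beyond the scatter) and shows that the core's other group also moves the number. The standing of compound 1 said little about the amine nitrogen group alone.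

The step from compound 3 to compound 4 swaps both the substituent and its numbered place on the ring, so 4-methoxyphenyl or 3-hydroxyphenyl would be needed to separate those two changes. The compounds shown offer no measurement that explains any of these differences.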